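A few compounds are considered here, and "the series" means these few. Any claim that something is new, unique, unknown or untested is made for them only; others in the source may bear on it.

Working notes on the series. In an ADME assay on BJ cells (Homo sapiens) for cytotoxicity, with a stated time of 72 h (on this read-out lower numbers stand for an effect already at smaller amounts and higher numbers for an effect only at larger amounts of compound), compound 1 (`COc1cc2ncnc(-n3nc(-c4ccncc4)nc3N)c2cc1OC`) stands as "not determined" (no result reported) and offers no anchor. Compound 2 (`COc1cc2ncnc(-n3nc(-c4ccccn4)nc3N)c2cc1OCCCN(C)C`) gives > 25000 nM as a limit of the assay, not a number. Its position is therefore only the limit of > 25000 nM in this assay, at which 1 of the 2 values shown sits, and no single number can be given for it. Compound 3 (`CCOC(=O)NCCCOc1cc2c(-n3nc(-c4ccccn4)nc3N)ncnc2cc1OC`) follows from compound 2 by (ethoxycarbonyl)amino in place of dimethylamino on a saturated chain carbon, three bonds along the chain from an oxygen on an aromatic ring and carries (ethoxycarbonyl)amino in place of dimethylamino on a saturated chain carbon, three bonds along the chain from an oxygen on an aromatic ring. Within the data shown here, no measured step sizes this change. The expected step that the limit leaves unreadable from compound 2 to compound 3 stays within the scatter in this assay and has no firm direction. For compound 3 the estimated value is 30000 nM with an expected range from 12000 nM to 75000 nM and a report as a limit alone is likely.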

Compound 3, half-maximal effective concentration: > 11000 nM
Compound 3: a limit, no number; the forecaster's own chance of this, stated with the estimate: 75%; the middle value lies beyond the limit too.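

Compound 2 and compound 3 both stand only as limits in this assay, not as numbers, so no step can be read between them. As far as these compounds go, whether (ethoxycarbonyl)amino in place of dimethylamino changes the half-maximal effective concentration at all, and in which direction, remains open.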